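This account rests on a few compounds, and the source may have more. Where it says the series, first, only, none or still open, it means among the compounds named here.

Compound 1 `O=c1[nH]cnc2c1c(-c1ccoc1)cn2[C@@H]1O[C@H](CO)[C@@H](O)[C@H]1O` is measured in a functional assay on HL-60 cells (Homo sapiens) for antiproliferative activity, read by XTT assay, with a stated time of 72 h (a lower number here means a stronger inhibitor, a higher number a weaker inhibitor), at 6370 nM.
Compound 2 `Cc1nc(N)c2c(-c3ccoc3)cn([C@@H]3O[C@H](CO)[C@@H](O)[C@H]3O)c2n1` reaches only the limit of this assay, > 20000 nM.
Compound 3 `O=c1[nH]cnc2c1c(-c1cc3ccccc3o1)cn2[C@@H]1O[C@H](CO)[C@@H](O)[C@H]1O` likewise reaches only the limit, > 20000 nM.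

Two of the three measured values thus sit at the limit, as noted in the limit of > 20000 nM in this assay, at which 2 of the 3 values shown sit. The core of compound 2 differs from the core of compound 1, but that difference is not broken down here. Between compound 1 and compound 3 there is one change, (1-benzofuran-2-yl in place of furan-3-yl on an aromatic carbon), and it gives an at least 3.1-fold higher number from compound 1 to compound 3 (0.49 log units; beyond the scatter) in this assay.

Compound 4 `Cc1nc(N)c2c(-c3cc4ccccc4o3)cn([C@@H]3O[C@H](CO)[C@@H](O)[C@H]3O)c2n1` has not been measured. It stands to compound 2 as compound 3 stands to compound 1: the same change, (1-benzofuran-2-yl in place of furan-3-yl on an aromatic carbon), on the same place. Since compound 2 already gives only the limit, > 20000 nM, and the same change weakened compound 1 toward compound 3, compound 4 is expected to remain at or beyond the limit, an estimated step that the limit leaves unreadable from compound 2 to compound 4. Compound 4 is therefore estimated at 40000 nM, between 15000 nM and 150000 nM.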

Compound 4, half-maximal inhibitory concentration: > 20000 nM
Compound 4 gave a limit, no number; the forecaster's own chance of this, stated with the estimate: 90%; the middle value lies beyond the limit too.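

Compound 4 gives only a limit in this assay, > 20000 nM, not a number. Compound 2 also gives only a limit, so no step can be read between these two compounds: the limit of > 20000 nM in this assay, at which 3 of the 4 values shown sit.

The compounds shown leave open what numbers compound 2 and compound 4 would give, and whether 1-benzofuran-2-yl in place of furan-3-yl changes activity on their core as it does on the core of compound 1.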